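The source may report more compounds than this note shows. Statements on the series, on what has been measured and on what is new or still open speak of the compounds shown alone.

Compounds measured so far:

- compound 1 `CCOC(=O)c1sc(-c2ccccc2)nc1OC` — > 100000 nM
- compound 2 `O=C(c1sc(-c2cccc(F)c2)nc1O)N1CCCCCO1` — 32 nM
- compound 3 `CCOC(=O)c1sc(-c2ccc(F)cc2)nc1O` — 80 nM

All three were tested in an assay on HEK293 cells for inhibition of transient receptor potential cation channel subfamily M member 8 (Homo sapiens), read by FLIPR, with stated times of 5 min and 3 min; a lower number here means a stronger inhibitor, a higher number a weaker inhibitor. Compound 1 gives only a limit of the assay and not a number, sitting at the limit of > 100000 nM in this assay, at which 1 of the 3 values shown sits. Of the two numbers, compound 3 stands at the higher one, while compound 2 gives the lower; the gap between them is beyond the usual scatter of repeated measurements, so compound 2 is the stronger inhibitor of the two.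

Compound 4 `CCOC(=O)c1sc(-c2ccc(Cl)cc2)nc1O` has not yet been measured. It differs from compound 3 in one place: chloro in place of fluoro on an aromatic carbon.

No step between two measured compounds isolates this change, so there is nothing shown here to set its size. The expectation is a small step, if any, in the direction of a somewhat lower number. The step from compound 3 to compound 4, estimated as a 1.6-fold lower number from compound 3 to compound 4 (0.20 log units; within the scatter), is expected to lie within the scatter. Compound 4 is therefore estimated at 50 nM, with a range from 15 nM to 200 nM.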

Compound 4, half-maximal inhibitory concentration: 550 nM
Estimate against measurement, compound 4: 11-fold (1.04 log units) below; the measured number lies above the stated range.
By their numbers in this assay, from the lowest: compound 2; then compound 3; then compound 4. At a limit, above all of these: compound 1.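

Among these compounds, this is the first step that isolates a single change, and it shows that the aromatic carbon para to a large group is sensitive to which halogen it carries: in this assay, chloro in place of fluoro gives a 6.9-fold higher number from compound 3 to compound 4 (0.84 log units; beyond the scatter). Fluoro and chloro are alike in everything counted for them here, yet the swap clearly moves the compound toward a weaker inhibitor. Nothing measured here gives a cause for this step.

On these data alone, whether a methyl group, a methoxy group or plain hydrogen on this carbon would stand nearer compound 3 or compound 4 remains open, so it cannot be said whether fluoro helps or chloro hurts. As far as these compounds go, it is also open whether the same change would act alike in compound 2, which differs from compound 3 in more than one place.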